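Positional isomers of a dichlorophenoxy group at the MCH1 receptor

This account rests on a few compounds, and the source may have more. Where it says the series, first, only, none or still open, it means among the compounds named here.

Measured compounds:
compound 1 `Cc1ccc(Oc2cccc(CN3CCC(c4cccc(NC(=O)C(C)C)c4)CC3)c2)cc1` — "not determined" (no result reported)
compound 2 `CC(C)C(=O)Nc1cccc(C2CCN(Cc3cccc(Oc4ccc(Cl)c(Cl)c4)c3)CC2)c1` — 2600 nM

In a functional assay on HEK293 cells for antagonist activity at melanin-concentrating hormone receptor 1 (Rattus norvegicus), read by FLIPR (on this read-out higher numbers stand for weaker inhibition and lower numbers for stronger inhibition), compound 2 gives 2600 nM. For the measured compounds named here, compound 1, which carries a methyl-substituted phenoxy group in the same position, gives "not determined" (no result reported) in this assay, so compound 2 stands as the only number available, and nothing can be said about its rank relative to another compound.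

Compound 3 `CC(C)C(=O)Nc1cccc(C2CCN(Cc3cccc(Oc4cc(Cl)cc(Cl)c4)c3)CC2)c1` is the unmeasured entry. It differs from compound 2 by 3,5-dichlorophenyl in place of 3,4-dichlorophenyl on an oxygen on an aromatic ring. Going by the values given here, no step between two measured compounds is available to calibrate what this exchange does, and compound 1 contributes no number. The expectation for the step from compound 2 to compound 3 is therefore one of no change beyond the scatter, no change at the digits printed from compound 2 to compound 3 (within the scatter). On that basis compound 3 is estimated at 2600 nM in this assay, with a range from 700 nM to 9000 nM.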

Compound 3, half-maximal inhibitory concentration: 1400 nM
Estimate against measurement, compound 3: 1.9-fold (0.27 log units) above, and the stated range covers the measured number.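

In this assay, for the compounds shown here, 3,5-dichlorophenyl in place of 3,4-dichlorophenyl on the oxygen gives a 1.9-fold lower number from compound 2 to compound 3 (0.27 log units; within the scatter), the first step that can be read at this position. The two chlorine patterns therefore cannot be told apart on this read-out, and this exchange of patterns has no effect here that rises above the usual scatter. Nothing available bears on why the two isomers read alike.

The compounds shown leave open whether the chlorine atoms matter at all, since an unsubstituted phenyl, a single chlorine or a methoxy group on this ring would test that directly. They also leave open whether an amine or a carboxylic acid on this ring, or the same exchange on a different core, would give a number that stands apart from these two.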